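Iodo for Chloro on a Weakly Cytotoxic Hydrazone

The source may hold more compounds than are shown below. What is called first, only, known or untested is meant among the compounds shown, and "the series" means these compounds.

Compound 1 `COc1ccc(C(=O)N/N=C/c2cc(I)c(O)c(I)c2)cc1`, compound 2 `O=C(N/N=C/c1cc(I)c(O)c(I)c1)c1ccc(O)cc1` and compound 3 `O=C(N/N=C/c1cc(I)c(O)c(I)c1)c1ccc(Cl)cc1` share one core and differ only in the group on the benzoyl ring. In a functional assay on HepG2 cells (Homo sapiens) for cytotoxicity, with a stated time of 24 h (a lower number here means a stronger inhibitor, a higher number a weaker inhibitor), compound 1 gives > 100000 nM, which is a limit of the assay and not a number. In this assay compound 2 gives 110000 nM. In this assay compound 3 gives > 100000 nM, again a limit rather than a number. Compound 3 thus stands at the limit of > 100000 nM in this assay, at which 2 of the 3 values shown sit. Going by the values given here, the steps a step that the limit leaves unreadable from compound 1 to compound 2, a step that the two limits leave unreadable from compound 1 to compound 3 and a step that the limit leaves unreadable from compound 2 to compound 3 cannot be read in size, so no measured step gives a usable direction for the next change. Compound 4 `O=C(N/N=C/c1cc(I)c(O)c(I)c1)c1ccc(I)cc1` differs from compound 3 by iodo in place of chloro on an aromatic carbon. With every comparable change among compounds 1, 2 and 3 unreadable, the expectation rests on where compound 3 itself stands. Compound 4 is therefore expected to give about 150000 nM in this assay, within a range of 60000 nM to 400000 nM, most likely reported again as a limit. The step that the limit leaves unreadable from compound 3 to compound 4 is expected to be none beyond the scatter.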

Compound 4, half-maximal inhibitory concentration: > 50000 nM
Compound 4: only a limit was reported; the forecaster's own chance of this, stated with the estimate: 80%; the middle value lies beyond the limit too.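

Compound 4 stands at a limit of the assay and not at a number: the limit of > 50000 nM in this assay, at which 1 of the 4 values shown sits. Going by these compounds alone, no step from compound 1, compound 2 or compound 3 to compound 4 can be read in size. The compounds shown leave open whether any of these groups on the benzoyl ring changes the cytotoxicity in this assay.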